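Methoxy added on the aryl ring: expected cytotoxicity outcome

The source may hold more compounds than are shown below. What is called first, only, known or untested is meant among the compounds shown, and "the series" means these compounds.

Compound 1 `COc1ccc(-c2cc(C(=O)Nc3nc4ccc(Cl)cc4s3)nc3cc(-c4ccccc4)nn23)cc1OC` and compound 2 `COc1cc(-c2cc(C(=O)Nc3nc4ccc(Cl)cc4s3)nc3cc(-c4ccccc4)nn23)cc(OC)c1OC` share one core; compound 3 `COc1ccc(-c2cc(C(=O)Nc3nc4ccc(OC)cc4s3)nc3cc(-c4ccccc4)nn23)cc1` carries another, and the difference between the two cores is not broken down here. In a functional assay on A549 cells (Homo sapiens) for cytotoxicity, read by MTT assay, with a stated time of 48 h (on this read-out higher numbers stand for weaker inhibition and lower numbers for stronger inhibition), compound 1 gives 6160 nM, compound 2 gives 18200 nM and compound 3 gives 17400 nM. The change from compound 1 to compound 2, (methoxy in place of hydrogen on an aromatic carbon), is the same kind of change as that leading to compound 4 `COc1ccc2nc(NC(=O)c3cc(-c4ccc(OC)c(OC)c4)n4nc(-c5ccccc5)cc4n3)sc2c1`, (methoxy in place of hydrogen on an aromatic carbon); around the place they differ in that the first is also meta to a methoxy group. The measured step was a 3.0-fold higher number from compound 1 to compound 2 (0.47 log units; beyond the scatter). For the measured compounds named here, for compound 4 the expected step is a 1.8-fold higher number from compound 3 to compound 4 (0.26 log units; within the scatter), resting on a 3.0-fold higher number from compound 1 to compound 2 (0.47 log units; beyond the scatter), the only example of this kind of change here. Compound 4 is thus expected at 32000 nM, with a range from 12000 nM to 85000 nM.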

Compound 4, half-maximal inhibitory concentration: 15800 nM
Compound 4: middle estimate off by 2.0-fold (0.31 log units), on the high side; measured number inside the range.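

In this assay, the change from 4-methoxyphenyl to 3,4-dimethoxyphenyl gives a 1.1-fold lower number from compound 3 to compound 4 (0.04 log units; within the scatter), so the size of the step on the core of compound 1 does not carry over to the core of compound 3: the same change on two cores in this assay, a 3.0-fold higher number (0.47 log units; beyond the scatter) from compound 1 to compound 2 and a 1.1-fold lower number (0.04 log units; within the scatter) from compound 3 to compound 4, 3.3-fold (0.51 log units) apart, beyond the scatter of two such steps

Methoxy in place of chloro, the one place separating the two cores, gives a 2.6-fold higher number from compound 1 to compound 4 (0.41 log units; beyond the scatter). With a single pair on each core, this shows a core dependence only for these four compounds and does not show why the steps differ or whether the gap would hold for other aryl groups.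

Open, from the compounds shown here alone, is whether a hydroxy group or an amine in place of the added methoxy would show the same core dependence. Also open, going by these compounds, is how a fluoro group or a carboxylic acid in place of chloro would behave.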